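Trimming the Amine Side Chain: Compound 1 to Compound 4

This account rests on a few compounds, and the source may have more. Where it says the series, first, only, none or still open, it means among the compounds named here.

Of the compounds shown here, three sharing one core have been measured in an assay on HEK293 cells for displacement of a labelled ligand from growth hormone secretagogue receptor type 1 (Homo sapiens), with a stated time of 60 min; a lower number here means a stronger inhibitor, a higher number a weaker inhibitor. Compound 1 `COCCNCCCS(=O)(=O)c1ccc2nc(NC(=O)NC(=O)c3ccccc3Cl)sc2c1` gives 8.6 nM in this assay. Compound 2 `CN1CCN(CCCS(=O)(=O)c2ccc3nc(NC(=O)NC(=O)c4cc(N5CCCC5)c(C#N)cc4Cl)sc3c2)CC1` gives 0.24 nM, and compound 3 `COc1cc(Cl)c(C(=O)NC(=O)Nc2nc3ccc(S(=O)(=O)CCCN4CCN(C)CC4)cc3s2)cc1-n1cccn1` gives 0.62 nM. Compound 1 thus stands with the highest number of the three; its nearest neighbour is compound 3 and its most distant is compound 2, and both gaps lie beyond the usual scatter of this assay.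

Compound 4 `CC(C)NCCS(=O)(=O)c1ccc2nc(NC(=O)NC(=O)c3ccccc3Cl)sc2c1` has not yet been measured in this assay. It differs from compound 1 in one place: isopropylamino in place of ((2-methoxyethyl)amino)methyl on a saturated chain carbon, two bonds along the chain from a sulfonyl sulfur. Going by the values given here, no pair among the measured compounds differs in exactly this way, so there is no directly comparable step to lean on, and compounds 2 and 3 differ from compound 1 in several places at once, so their numbers say little about this single swap. The step from compound 1 to compound 4 is expected to be small, a 1.2-fold higher number from compound 1 to compound 4 (0.07 log units; within the scatter), with no clear direction beyond the scatter. Compound 4 is estimated to give 10 nM in this assay, within a range from 3 nM to 35 nM.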

Compound 4, half-maximal inhibitory concentration: 27 nM
Estimate against measurement, compound 4: 2.7-fold (0.43 log units) below; the range from low to high includes it.
By their numbers in this assay, from the lowest: compound 2; then compound 3; then compound 1; then compound 4.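

In this assay, going by these compounds alone, swapping ((2-methoxyethyl)amino)methyl for isopropylamino gives a 3.1-fold higher number from compound 1 to compound 4 (0.50 log units; beyond the scatter) and so offers the first comparison in which only one place differs. With the rest of compound 1 held fixed, this change on the saturated chain carbon moves the number beyond the scatter, so the side chain is not a silent part of the molecule here, though the step is modest. Nothing measured here says what lies behind the step.

The chain length and the amine end change together in this swap, leaving open which of them matters; a 3-(isopropylamino)propyl chain would separate the two. As far as these compounds go, how a morpholine at the end of the chain would compare on the core of compound 1 also remains open.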